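Ethoxycarbonyl in Place of Hydroxymethyl: An Expected Step

This account rests on a few compounds, and the source may have more. Where it says the series, first, only, none or still open, it means among the compounds named here.

Compound 1 `O=C(CCl)Nc1cccc(Cn2nc(-c3ccc(Oc4ccccc4)cc3)cc2CO)c1`: 400 nM
Compound 2 `C/C=C/C(=O)N1CCCC(n2nc(-c3ccc(Oc4ccccc4)cc3)cc2C(=O)OCC)C1`: 26500 nM

Of the compounds shown here, two have been measured in a functional assay on JeKo-1 cells (Homo sapiens) for inhibition, read by luminescence and CellTiter-Glo, with a stated time of 72 h; on this read-out lower numbers stand for stronger inhibition and higher numbers for weaker inhibition. Compound 1 gives 400 nM and stands lowest of the two numbers. Compound 2 gives 26500 nM, a far higher number, and the gap between them lies beyond the usual scatter. Within the data shown here, the two differ in several places at once, so no single step between them is defined, and their two values show only that compound 1 is the stronger of the pair.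

Compound 3 `CCOC(=O)c1cc(-c2ccc(Oc3ccccc3)cc2)nn1Cc1cccc(NC(=O)CCl)c1` has not yet been measured. It differs from compound 1 in one place: ethoxycarbonyl in place of hydroxymethyl on an aromatic carbon. Compound 2 also carries an ethoxycarbonyl at this position, but it differs from compound 1 elsewhere as well, so its value cannot be read as a step for this group alone. Among the measured compounds shown here, with no isolating step available, the expectation rests on compound 1 alone, and a moderate weakening is expected for compound 3, on the order of a 2.5-fold higher number from compound 1 to compound 3 (0.40 log units; beyond the scatter) in this assay. Compound 3 is therefore estimated at 1000 nM, with a range from 250 nM to 4000 nM.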

Compound 3, half-maximal inhibitory concentration: 400 nM
For compound 3 the middle estimate is 2.5-fold (0.40 log units) above the measured one, and the stated range covers the measured number.
By their numbers in this assay, from the lowest: compounds 1 and 3 (each within the scatter of the next); then compound 2.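

In this assay, putting ethoxycarbonyl in place of hydroxymethyl on an aromatic carbon of the five-membered aromatic ring gives no change at the digits printed from compound 1 to compound 3 (within the scatter). Among these compounds, this is the first isolated reading at this position, and it shows that, with the rest of compound 1 unchanged, the read-out does not separate the two groups, even though the entering group has more heavy atoms, carries a double bond outside aromatic rings and has no hydrogen-bond donor, whereas hydroxymethyl has one. Nothing among the available data explains why the two groups read alike.

Among the compounds shown here, the single step leaves open whether other groups on this aromatic carbon would also read within the scatter of compound 1, such as a carboxylic acid, a primary amide, an aminomethyl group or a longer ester chain. It also leaves open whether the same exchange would read alike with a different group on the ring nitrogen, as one pair on one core cannot establish a wider pattern.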